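Halogen swap on the aryl ketone of the shared core

The source may hold more compounds than are shown below. What is called first, only, known or untested is meant among the compounds shown, and "the series" means these compounds.

Measured so far:
compound 1 `O=C(c1cccnc1)c1cc2c(-c3cccnc3)nn(-c3ccccc3)c2[nH]c1=O` gives 11 ug/mL in a functional assay on HepG2 cells (Homo sapiens) for cytotoxicity, read by sulforhodamine B assay; a higher number here means a weaker inhibitor, a lower number a stronger inhibitor
compound 2 `O=C(c1ccc(Cl)cc1)c1cc2c(-c3cccnc3)nn(-c3ccccc3)c2[nH]c1=O` gives 9 ug/mL in this assay
compound 3 `N#Cc1cc2c(-c3cccnc3)nn(-c3ccccc3)c2[nH]c1=S` gives 3.9 ug/mL in this assay

Compound 2 stands second highest of these three numbers; compound 1 sits nearest, within the scatter, while compound 3 lies furthest, beyond it.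

Compound 4 `O=C(c1ccc(F)cc1)c1cc2c(-c3cccnc3)nn(-c3ccccc3)c2[nH]c1=O` is not yet measured. It differs from compound 2 by fluoro in place of chloro on an aromatic carbon. For the measured compounds named here, only one measured step touches this carbonyl aryl group: a 1.2-fold lower number from compound 1 to compound 2 (0.09 log units; within the scatter), a swap of the whole ring that stayed within the scatter. Exchanging one halogen for another on that ring is a smaller change still, so no step beyond the scatter is expected in this assay.

Compound 4 is therefore estimated at 10 ug/mL, range 5 ug/mL to 20 ug/mL, meaning an expected step of a 1.1-fold higher number from compound 2 to compound 4 (0.05 log units; within the scatter).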

Compound 4, half-maximal inhibitory concentration: 7.8 ug/mL
Compound 4: middle estimate off by 1.3-fold (0.11 log units), on the high side, within the range that was stated.
By their numbers in this assay, from the lowest: compounds 3, 4, 2 and 1 (each within the scatter of the next, the first and the last beyond it).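

In this assay fluoro in place of chloro gives a 1.2-fold lower number from compound 2 to compound 4 (0.06 log units; within the scatter) and 4-fluorophenyl in place of pyridin-3-yl gives a 1.4-fold lower number from compound 1 to compound 4 (0.15 log units; within the scatter) so neither the halogen exchange nor the ring swap moves the number beyond the scatter. With three aryl groups on this carbonyl, the number stays within the scatter across every step at this position. Nothing available bears on why these changes leave the number so little moved.

Still open, going by these compounds, is whether an amine, a carboxylic acid or a longer chain in place of the halogen on this ring would give a step beyond the scatter.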